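Methoxyphenyl positional isomers in a thiazolyl ketone series

A few compounds are considered here, and "the series" means these few. Any claim that something is new, unique, unknown or untested is made for them only; others in the source may bear on it.

Measured compounds:
compound 1 `COc1ccc(-c2nc(C)c(C(=O)CSc3nc(N)c(C#N)c(-c4ccc(Cl)cc4)n3)s2)cc1` 23.1%
compound 2 `COc1ccc(-c2nc(SCC(=O)c3sc(-c4ccccc4)nc3C)[nH]c(=O)c2C#N)cc1` 52.1%
compound 3 `COc1ccc(-c2nc(C)c(C(=O)CSc3nc(-c4ccc(Cl)cc4)c(C#N)c(=O)[nH]3)s2)cc1` 48%

In a functional assay on U-87MG ATCC cells for antiproliferative activity against U-87 MG (Homo sapiens), read by MTT assay, with a stated time of 48 h, tested at 50 uM (on this read-out lower numbers stand for a stronger effect and higher numbers for a weaker effect at the one concentration tested), compound 2 gives 52.1%, the highest of the three numbers. Compound 3, at 48%, sits within the scatter of compound 2, so no order between those two can be stated. Compound 1, at 23.1%, lies beyond the scatter below compound 2 and so shows the stronger effect of the pair.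

Compound 4 `COc1cccc(-c2nc(SCC(=O)c3sc(-c4ccccc4)nc3C)[nH]c(=O)c2C#N)c1` is not yet measured. It differs from compound 2 by 3-methoxyphenyl in place of 4-methoxyphenyl on an aromatic carbon: the same atoms joined differently, with the methoxy group moved on the six-membered aromatic ring of carbon only, attached on an aromatic carbon of the core. Among the compounds with values here, no step between measured compounds of this kind is available, so nothing tells the direction of such a change.

The step expected from compound 2 to compound 4, a number 0.1 percentage points lower from compound 2 to compound 4 (within the scatter), is therefore none beyond the scatter. Compound 4 is estimated at 52%, with a range from 34% to 70%, pending the measurement.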

Compound 4, a percentage reported as activity, at one concentration (the size of the read-out at that concentration, not a potency): 80.3%
Estimate against measurement, compound 4: 28.3 percentage points below; measured number above the stated range.
By their numbers in this assay, from the lowest: compound 1; then compounds 3 and 2 (each within the scatter of the next); then compound 4.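

In this assay, within the data shown here, this is the first readable single-place change: 3-methoxyphenyl in place of 4-methoxyphenyl gives a number 28.2 percentage points higher from compound 2 to compound 4 (beyond the scatter), a weaker effect at the one concentration tested. The position on the aromatic carbon ortho to a cyano group is therefore sensitive to where the methoxy group sits on the phenyl ring, even with the same atoms and the same counted donors and acceptors. Nothing available bears on the reason for this difference.

Still open, on these data alone, is whether a plain phenyl, a 4-hydroxyphenyl or a 4-dimethylaminophenyl at this position would give a stronger effect than the 4-methoxyphenyl of compound 2. Also open, as far as these compounds go, is whether moving the methoxy group has a comparable effect on the methoxyphenyl of compound 1 or compound 3.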